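Chloro on the Phenylsulfonyl Group of Compound 1

This account rests on a few compounds, and the source may have more. Where it says the series, first, only, none or still open, it means among the compounds named here.

Measured compounds:
compound 1 `Cc1ccc(-n2cc(NC(=O)c3cccc(NS(=O)(=O)c4ccccc4)c3)cn2)cc1`: 1690 nM
compound 2 `COc1ccc(-n2cc(NC(=O)c3cccc(NS(=O)(=O)c4ccccc4)c3)cn2)cc1`: 18700 nM
compound 3 `COc1cccc(-n2cc(NC(=O)c3cccc(NS(=O)(=O)c4ccccc4)c3)cn2)c1`: 16700 nM

In a functional assay on MCF7 cells (Homo sapiens) for inhibition, read by MTT assay, with a stated time of 48 h (on this read-out higher numbers stand for weaker inhibition and lower numbers for stronger inhibition), compound 1 gives the lowest number of the three; the steps of a 9.9-fold higher number from compound 1 to compound 3 (0.99 log units; beyond the scatter) and an 11-fold higher number from compound 1 to compound 2 (1.04 log units; beyond the scatter) both lie beyond the scatter. Compound 4 `Cc1ccc(-n2cc(NC(=O)c3cccc(NS(=O)(=O)c4ccc(Cl)cc4)c3)cn2)cc1` differs from compound 1 by chloro in place of hydrogen on an aromatic carbon, para to a large group. Going by the values given here, none of the measured steps touches this part of the shared core; all of them alter the aryl group on the pyrazole nitrogen, so they bear on the change only in showing how sensitive this assay is to small changes elsewhere. Among the compounds with values here, with no direct precedent, compound 4 is expected to give a number near that of compound 1, around 1500 nM, with a range of 500 nM to 5000 nM. This estimate corresponds to a 1.1-fold lower number from compound 1 to compound 4 (0.05 log units; within the scatter), no step beyond the scatter.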

Compound 4, half-maximal inhibitory concentration: 1080 nM
For compound 4 the middle estimate is 1.4-fold (0.14 log units) above the measured one, within the range that was stated.
By their numbers in this assay, from the lowest: compounds 4 and 1 (each within the scatter of the next); then compounds 3 and 2 (each within the scatter of the next).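

In this assay the step at this position is a 1.6-fold lower number from compound 1 to compound 4 (0.19 log units; within the scatter), so the phenylsulfonyl group of compound 1 accepts chloro, para to a large group, with no change that stands out from the scatter. The earlier steps shown here, all made elsewhere on the shared core, gave no reading at this position. No measurement shown here offers an explanation for this result. Open, from the compounds shown here alone, is whether an amine or a carboxylic acid in the same place would read like chloro. Also open, going by these compounds, is whether chloro would behave the same way on compound 2 or compound 3.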